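Trading a Methoxy for Methyl on a Sulfone Aryl Ring

The compounds below may be only part of what the source reports. "The series", "measured", "known", "first", "only" and "open" are said of these compounds alone.

Of the compounds shown here, three built on one shared core have been tested in an assay on isolated protein for displacement of a labelled ligand from metabotropic glutamate receptor 5 (Homo sapiens), with a stated time of 60 min, tested at 1 uM; a lower number here means less inhibition, a higher number more inhibition at the concentration tested (going by the name of the read-out). Compound 1 `COc1ccc2ncc(S(=O)(=O)c3ccc(OC)c(Cl)c3)c(N3CCC(C)CC3)c2c1` gives 21%. Compound 2 `COc1ccc(S(=O)(=O)c2cnc3ccc(F)cc3c2N2CCC(C)CC2)cc1Cl` gives 82%, and compound 3 `COc1ccc(S(=O)(=O)c2cnc3ccc(Cl)cc3c2N2CCC(C)CC2)cc1Cl` gives 46%. Compound 1 thus stands lowest of the three: compound 3 is the nearest, a number 25 percentage points higher from compound 1 to compound 3 (beyond the scatter), and compound 2 the furthest, a number 61 percentage points higher from compound 1 to compound 2 (beyond the scatter). Between the two halogen compounds the shift is a number 36 percentage points lower from compound 2 to compound 3 (beyond the scatter).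

Compound 4 `COc1ccc2ncc(S(=O)(=O)c3ccc(C)c(Cl)c3)c(N3CCC(C)CC3)c2c1` is not yet measured. It differs from compound 1 in one place: methyl in place of methoxy on an aromatic carbon. Each measured step also removes a methoxy group, yet each puts a halogen in its place, and none puts a methyl there, so the measured steps bear on this change only by analogy. Both halogen replacements raised inhibition, once by a modest amount and once by a large one, so a rise is expected for compound 4 too, though its size is uncertain. The step expected in this assay is a number 19 percentage points higher from compound 1 to compound 4 (beyond the scatter). Compound 4 is estimated at 40%, within a range from 15% to 70%.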

Compound 4, a percentage reported as inhibition, at one concentration (the size of the read-out at that concentration, not a potency): 85%
The estimate for compound 4 lay 45 percentage points below the measured number, outside the stated range (above it).
By their numbers in this assay, from the lowest: compound 1; then compound 3; then compounds 2 and 4 (each within the scatter of the next).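

For the compounds shown here, until now, only the methoxy on the shared core had been changed, so compound 4 is the first look at the other methoxy, on the sulfone aryl ring, para to a large group and ortho to a chloro group. In this assay, going from 3-chloro-4-methoxyphenyl to 3-chloro-4-methylphenyl gives a number 64 percentage points higher from compound 1 to compound 4 (beyond the scatter), which shows that this second position also strongly affects the read-out, and that a carbon-only methyl can take the place of methoxy here without loss of inhibition. The change removes one oxygen and one hydrogen-bond acceptor, yet the data available offer no measurement that explains why inhibition moves so far with it.

Still open, going by these compounds, is whether the rise is particular to methyl, or whether an ethyl, a fluoro, an amine or a carboxylic acid at the same position would behave alike. On these data alone, it is also open whether this methyl change and the fluoro change on the core would add up in one molecule, and how any of this would look as a true potency, given that the read-out here is inhibition at a single concentration.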